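The compounds below may be only part of what the source reports. "The series", "measured", "known", "first", "only" and "open" are said of these compounds alone.

Compound 1, `COc1cc(C)cc(-c2c(-c3ccnc(-c4ccc(C(C)=O)cc4)c3)cnn2CC#N)c1`: 16%
Compound 2, `COc1cc(C)cc(-c2nn(CC#N)cc2-c2ccc(-c3cccc(C(C)=O)c3)nc2)c1`: -38%
Compound 3, `Cc1cc(O)cc(-c2nn(CC#N)cc2-c2ccnc(-c3ccc(N(C)C)cc3)c2)c1`: -7%

These numbers come from a functional assay on DU-145 cells (Homo sapiens) for cytotoxicity, read by sulforhodamine B assay, with a stated time of 48 h, tested at 1 uM; on this read-out higher numbers stand for a weaker effect at the one concentration tested and lower numbers for a stronger effect. Among the three, compound 1 stands highest, giving 16%; compound 3 comes nearest with -7%, a gap beyond the scatter, and compound 2 lies furthest with -38%. Compound 4, `COc1cc(C)cc(-c2c(-c3ccnc(-c4ccc(N(C)C)cc4)c3)cnn2CC#N)c1`, has not yet been tested. It differs from compound 1 in one place: dimethylamino in place of acetyl on an aromatic carbon. For the measured compounds named here, no measured pair shares this single change, so its size is open. Compound 3 also carries a dimethylamino group, though on a different core, and gives -7% in this assay, which suggests a lower number for compound 4, by about the scatter or slightly beyond. Compound 4 is therefore expected to give 0%, with a range from -25% to 25%. The expected step is a number 16 percentage points lower from compound 1 to compound 4 (beyond the scatter).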

Compound 4, a percentage reported as activity, at one concentration (the size of the read-out at that concentration, not a potency): -47%
For compound 4 the middle estimate is 47 percentage points above the measured one; the whole stated range lies above it.
By their numbers in this assay, from the lowest: compounds 4 and 2 (each within the scatter of the next); then compound 3; then compound 1.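

Swapping acetyl for dimethylamino on the aromatic carbon para to a large group gives a large change in this assay, with a number 63 percentage points lower from compound 1 to compound 4 (beyond the scatter) on the shared core. For the compounds shown here, this is the only single change here whose size can be read, and it shows that this position alone can move the read-out strongly towards a stronger effect. Nothing measured here explains the size of this step. Going by these compounds, whether a primary amine or a carboxylic acid at this position would give a similar number stays open. So does whether the same change would have a similar effect on another core.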